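Pyridyl chalcone series: cytotoxicity on monocytic cells

A few compounds are considered here, and "the series" means these few. Any claim that something is new, unique, unknown or untested is made for them only; others in the source may bear on it.

Measured compounds:
compound 1, `COc1cc(OCC=C(C)C)ccc1C(=O)/C=C/c1ccncc1`, 16000 nM
compound 2, `COc1cc(OCC=C(C)C)ccc1C(=O)/C=C/c1cccnc1`, 40000 nM
compound 3, `C#CCOc1ccc(C(=O)/C=C/c2ccncc2)c(OCC#C)c1`, 11000 nM

All three values come from an ADME assay on THP-1 cells (Homo sapiens) for cytotoxicity, read by resazurin assay, with a stated time of 72 h; on this read-out higher numbers stand for lower toxicity in this test and lower numbers for higher toxicity in this test. Compound 1 and compound 2 share a core and differ in one place:
pyridin-3-yl in place of pyridin-4-yl on a double-bonded chain carbon bound to a double-bonded chain carbon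
That change gave a 2.5-fold higher number from compound 1 to compound 2 (0.40 log units; beyond the scatter).

Compound 3 carries a different core; the difference between the core of compound 1 and the core of compound 3 is not broken down here. Among the three measured numbers compound 3 has the lowest, but its value and that of compound 1 lie within the usual scatter, so no order between those two is claimed; against compound 2 the gap is beyond the scatter.

Compound 4, `C#CCOc1ccc(C(=O)/C=C/c2cccnc2)c(OCC#C)c1`, is not yet measured. It differs from compound 3 as follows:
pyridin-3-yl in place of pyridin-4-yl on a double-bonded chain carbon bound to a double-bonded chain carbon
This is the same change that turned compound 1 into compound 2, made on the core of compound 3. Within the data shown here, the expected step from compound 3 to compound 4 in this assay is a 2.3-fold higher number from compound 3 to compound 4 (0.36 log units; beyond the scatter), resting on the single earlier instance a 2.5-fold higher number from compound 1 to compound 2 (0.40 log units; beyond the scatter) and carrying the uncertainty of a change seen once. Compound 4 is therefore estimated at 25000 nM, with a range from 12000 nM to 55000 nM.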

Compound 4, half-maximal cytotoxic concentration: 15000 nM
The estimate for compound 4 lay 1.7-fold (0.22 log units) above the measured number; the measured number falls inside the stated range.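

In this assay, pyridin-3-yl in place of pyridin-4-yl on the core of compound 3 gives a 1.4-fold higher number from compound 3 to compound 4 (0.13 log units; within the scatter), and set beside the earlier step the two instances do not separate: the same change on two cores in this assay, a 2.5-fold higher number (0.40 log units; beyond the scatter) from compound 1 to compound 2 and a 1.4-fold higher number (0.13 log units; within the scatter) from compound 3 to compound 4, 1.8-fold (0.26 log units) apart, within the scatter of two such steps

Among these compounds, the two steps are therefore compatible with one shared size for this change across both cores, although only the step on the core of compound 1 stands beyond the scatter. Two pairs do not show that the change carries over with a fixed size to further cores in this series, nor do they show that its size depends on the core.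

Open, as far as these compounds go, is how pyridin-2-yl, or a phenyl ring bearing a dimethylamino group, would read in this test on the same double-bonded chain carbon. Also open is whether the comparison would hold on a core carrying a longer chain, such as hexyloxy, in place of the ether groups of these compounds.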